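The source may hold more compounds than are shown below. What is called first, only, known or untested is meant among the compounds shown, and "the series" means these compounds.

Measured so far:
compound 1 `c1ccc(-c2ccc(Cn3cncc3CNc3cccc(-c4ccccc4)c3)cc2)cc1`, 10000 nM in a toxicity assay on NIH3T3 cells (Mus musculus) for cytotoxicity, read by resazurin assay; a lower number here means that less compound is needed, a higher number that more compound is needed for the effect
compound 2 `Clc1ccc(Cn2cncc2CNc2cccc(-c3ccccc3)c2)cc1`, 10000 nM in this assay

Compound 1 stands level with compound 2 in this assay; the step of no change at the digits printed from compound 1 to compound 2 (within the scatter) shows no change beyond the scatter. Compound 3 `c1ccc(-c2ccc(Cn3cncc3CNc3ccc(-c4onc5ccccc45)c(-c4ccccc4)c3)cc2)cc1` is not yet measured. It differs from compound 1 by a group of 9 heavy atoms (7 carbon, 1 nitrogen, 1 oxygen; one five-membered aromatic ring with 2 hetero atoms, one six-membered aromatic ring of carbon only) in place of a hydrogen atom, on an aromatic carbon. Within the data shown here, no measured step covers such an addition, and the one step known, no change at the digits printed from compound 1 to compound 2 (within the scatter), changed nothing. On these numbers compound 3 is expected to give 10000 nM, with a range of 3000 nM to 30000 nM, the step of no change at the digits printed from compound 1 to compound 3 (within the scatter) being estimated as none beyond the scatter.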

Compound 3, half-maximal effective concentration: > 10000 nM
Compound 3 ended at the assay's limit (the forecaster's own chance of this, stated with the estimate: 30%); the middle value sits exactly at the limit.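

In this assay compound 3 gives > 10000 nM, which is a limit of the assay and not a number. Compounds 1 and 2 carry only a hydrogen atom on this aromatic carbon, ortho to a phenyl group and para to a large group; compound 3 shows that the group of 9 heavy atoms can stand there without a lower number in this assay. The step reads a number no lower from compound 1 to compound 3 (the limit leaves the size open), and its size cannot be read: the limit of > 10000 nM in this assay, at which 1 of the 3 values shown sits.

Left open is whether an amine or a carboxylic acid on this carbon would give a lower number in this assay. Also open, on these data alone, is how far the value of compound 3 lies beyond the limit.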